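Benzyl in place of methyl on the aryl piperazine

This account rests on a few compounds, and the source may have more. Where it says the series, first, only, none or still open, it means among the compounds named here.

Working notes on a series that shares the core of compound 1 `CN(C)C(=O)c1cccnc1NCCCN1CCN(c2ccccc2O)CC1` and differs only in the group on the aromatic ring of the aryl piperazine. In a functional assay for antagonist activity at Alpha-1A adrenergic receptor (Oryctolagus cuniculus) (a lower number here means tighter binding, a higher number weaker binding), compound 1 gives 5.01 nM, compound 2 `CN(C)C(=O)c1cccnc1NCCCN1CCN(c2ccccc2OCC(F)(F)F)CC1` gives 0.1 nM, and compound 3 `Cc1ccccc1N1CCN(CCCNc2ncccc2C(=O)N(C)C)CC1` gives 2 nM, the second highest of the three numbers. The step to compound 4 `CN(C)C(=O)c1cccnc1NCCCN1CCN(c2ccccc2Cc2ccccc2)CC1` is phenyl in place of hydrogen on a saturated chain carbon bound to an aromatic carbon. For the measured compounds named here, no measured step matches it; the nearest is a 50-fold lower number from compound 1 to compound 2 (1.70 log units; beyond the scatter), where a larger group at the same ring lowered the number, while a 20-fold higher number from compound 2 to compound 3 (1.30 log units; beyond the scatter) shows methyl well above trifluoroethoxy. A modest lowering is therefore expected, a 2.5-fold lower number from compound 3 to compound 4 (0.40 log units; beyond the scatter). Compound 4 is estimated at 0.8 nM, range 0.15 nM to 4 nM.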

Compound 4, dissociation constant: 6.31 nM
Estimate against measurement, compound 4: 7.9-fold (0.90 log units) below, outside the stated range (above it).
By their numbers in this assay, from the lowest: compound 2; then compound 3; then compounds 1 and 4 (each within the scatter of the next).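

Methyl to benzyl does not lower the number in this assay (a 3.2-fold higher number from compound 3 to compound 4 (0.50 log units; beyond the scatter)), so compound 2 does not show that any larger group at this ring lowers it. Benzyl sits far from 2,2,2-trifluoroethoxy (a 63-fold higher number from compound 2 to compound 4 (1.80 log units; beyond the scatter)), while it cannot be told apart from hydroxy (a 1.3-fold higher number from compound 1 to compound 4 (0.10 log units; within the scatter)). Nothing available explains these differences.

The compounds shown leave open whether methoxy or a longer ether chain would give a number close to that of compound 2. They also leave open how an amine or a carboxylic acid on this ring would compare.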